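The source may report more compounds than this note shows. Statements on the series, on what has been measured and on what is new or still open speak of the compounds shown alone.

Measured in a functional assay on MCF7 cells (Homo sapiens) for cytotoxicity, read by MTT assay, with a stated time of 48 h; on this read-out lower numbers stand for stronger inhibition and higher numbers for weaker inhibition:
- compound 1 `CC(=NNC(=S)Nc1ccccc1F)c1ccccn1`: 0.39 nM
- compound 2 `CC(=NNC(=S)Nc1cccc([N+](=O)[O-])c1)c1ccccn1`: 38 nM
- compound 3 `C/C(=N\NC(=S)Nc1cccc(F)c1)c1ccccn1`: 9 nM

Compound 1 stands at the strong end of this small set. Its value of 0.39 nM is the lowest of the three numbers, and the gaps to the others lie well beyond the scatter. Compound 3 is the nearest at 9 nM, and compound 2 is the furthest at 38 nM.

The next compound to be tested in this assay is compound 4 `C/C(=N/NC(=S)Nc1ccccc1F)c1ccccn1`. The change from compound 1 is the two compounds have the same atoms and bonds; at least one stereo element is drawn with a configuration in one of them and without one in the other: 1 of 1 stereo elements differ; a double bond is drawn without a configuration in compound 1 and Z in compound 4. The two compounds have the same atoms and bonds, and only the drawing of that double bond separates them: without a configuration in compound 1 and Z in compound 4.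

Within the data shown here, the data hold no measured pair that differs in this way alone, so the expectation rests on compound 1 and its 0.39 nM. No step beyond the scatter is expected in this assay, and the estimated change is a 1.5-fold higher number from compound 1 to compound 4 (0.19 log units; within the scatter). Among the measured compounds shown here, the range is kept wider on the upper side, since no measured compound shows what a drawn configuration means here. For compound 4 the expected value is 0.6 nM, with an estimated range from 0.15 nM to 6 nM.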

Compound 4, half-maximal inhibitory concentration: 0.39 nM
Beside the measured number, compound 4's estimate is 1.5-fold (0.19 log units) above it, within the range that was stated.
By their numbers in this assay, from the lowest: compounds 1 and 4 (each within the scatter of the next); then compound 3; then compound 2.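

In this assay, among these compounds, the earlier compounds offered no pair that isolated a drawn configuration, and this pair supplies the first such reading at the double bond, with no change at the digits printed from compound 1 to compound 4 (within the scatter). Drawing this double bond as Z therefore brings no step beyond the scatter with the fluoro group and the rest of compound 1 held constant, so at this position the undefined drawing and the Z drawing cannot be told apart by this read-out, although the values alone cannot show whether the two entries describe the same material or different mixtures of forms. All that separates the two entries structurally is a matter of drawing, and no atom or bond enters or leaves, so the comparison reaches only as far as this: the fact that one of compounds 1 and 4 is drawn with a defined configuration and the other without, at the place where they differ.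

The compounds shown leave open what a pairing of the Z drawing with the opposite configuration at this double bond would read, since no such matched pair stands here. They also leave open whether the same absence of a step would hold with a chlorine atom or a methoxy group in place of the fluoro group of compound 1.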